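Hydrazone series: dichlorophenyl for dimethoxyphenyl on ring nitrogen

The source may report more compounds than this note shows. Statements on the series, on what has been measured and on what is new or still open speak of the compounds shown alone.

Measured so far:
compound 1 `COc1ccc(-n2c(-c3ccc(Cl)cc3)cs/c2=N\NC(=O)c2ccc(O)cc2)c(OC)c1` — < 100000 nM
compound 2 `Cc1ccc(-c2cs/c(=N\NC(=O)c3ccc(O)cc3)n2-c2c(C)cccc2C)cc1` — < 100000 nM
compound 3 `O=C(c1ccc(O)cc1)n1nc(-c2c(Cl)cccc2Cl)sc1=S` — 43700 nM

All three were run in a functional assay on HOP-92 cells (Homo sapiens) for cytotoxicity, read by sulforhodamine B assay, with a stated time of 48 h; on this read-out higher numbers stand for lower toxicity in this test and lower numbers for higher toxicity in this test. For compound 1 the value < 100000 nM is a limit of the assay, not a number. For compound 2 the value < 100000 nM is likewise a limit. Compound 3 gives 43700 nM, the only numerical result in the set. Compound 1 therefore stands only at a limit, and no more can be said of its place than the limit of < 100000 nM in this assay, at which 2 of the 3 values shown sit. For the measured compounds named here, no pair of measured compounds differs in a single place, so no measured step is available and no pattern can be drawn from the three.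

Compound 4 `O=C(N/N=c1\scc(-c2ccc(Cl)cc2)n1-c1ccc(Cl)cc1Cl)c1ccc(O)cc1` is yet to be measured. It differs from compound 1 in one place: 2,4-dichlorophenyl in place of 2,4-dimethoxyphenyl on an aromatic nitrogen. With compound 1 known only as a limit, the step in this assay cannot be anchored to a measured number; the expectation is for no change beyond the scatter, held with wide uncertainty. Compound 4 is expected at 45000 nM, with a range from 15000 nM to 100000 nM. This estimate means an expected step that the limit leaves unreadable from compound 1 to compound 4. Going by the values given here, the estimate leans on compound 3 giving 43700 nM as the only number in the set.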

Compound 4, concentration lethal to 50% of the cells: 49000 nM
Compound 4: the middle estimate sits 1.1-fold (0.04 log units) below what was measured; low and high end bracket the measured number.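

No step can be read from compound 1 to compound 4, because compound 1 stands only at a limit and not at a number: the limit of < 100000 nM in this assay, at which 2 of the 4 values shown sit. The compounds shown leave open the size and direction of any change in this assay with 2,4-dichlorophenyl in place of 2,4-dimethoxyphenyl on an aromatic nitrogen, with compound 4 at 49000 nM as the pair's only number.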